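Ester variation at the side-chain oxygen of the shared core

The compounds below may be only part of what the source reports. "The series", "measured", "known", "first", "only" and "open" are said of these compounds alone.

Compound 3 `CC(C)=CC[C@@H](OC(=O)C1CCCO1)C1=CC(=O)c2c(O)ccc(O)c2C1=O` holds the lowest of the two numbers obtained so far in a functional assay on HeLa cells (Homo sapiens) for cytotoxicity, read by MTT assay (a higher number here means a weaker inhibitor, a lower number a stronger inhibitor), where compound 3 gives 17000 nM. Compound 1 `COCCO[C@H](CC=C(C)C)C1=CC(=O)c2c(O)ccc(O)c2C1=O` gives 62400 nM in this assay, and the step of a 3.7-fold lower number from compound 1 to compound 3 (0.56 log units; beyond the scatter). Compound 2 `CCCCCCC(C)(O)CC(=O)O[C@H](CC=C(C)C)C1=CC(=O)c2c(O)ccc(O)c2C1=O` reaches only the limit of the assay, > 100000 nM, in this assay, so no number stands for it (the limit of > 100000 nM in this assay, at which 1 of the 3 values shown sits).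

Compound 4 `CCC(O)(CC)CC(=O)O[C@H](CC=C(C)C)C1=CC(=O)c2c(O)ccc(O)c2C1=O` differs from compound 3 in one place: 2-ethyl-2-hydroxybutyl in place of oxolan-2-yl on a carbonyl carbon. The step that bears on this change is an at least 5.8-fold lower number from compound 2 to compound 3 (0.76 log units; beyond the scatter), the reverse of which brings a 2-hydroxy-branched open chain onto the carbonyl carbon, as the 2-ethyl-2-hydroxybutyl group does here, though with a shorter chain than in compound 2. Taking the step from compound 2 to compound 3 as the guide and allowing for the shorter chain, compound 4 is expected to move upward from compound 3 by a 2.9-fold higher number from compound 3 to compound 4 (0.47 log units; beyond the scatter), beyond the scatter. Compound 4 is therefore estimated at 50000 nM, in the range 20000 nM to 150000 nM, with a real chance that only a limit is returned.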

Compound 4, half-maximal inhibitory concentration: 52000 nM
Estimate against measurement, compound 4: 1.0-fold (0.02 log units) below, and the stated range covers the measured number.
By their numbers in this assay, from the lowest: compound 3; then compounds 4 and 1 (each within the scatter of the next). At a limit, above all of these: compound 2.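

Replacing oxolan-2-yl on the carbonyl carbon with 2-ethyl-2-hydroxybutyl gives a 3.1-fold higher number from compound 3 to compound 4 (0.49 log units; beyond the scatter) in this assay, so a measured number now replaces the open-ended comparison that was available for this change. The open hydroxylated ester is not separated from the ether, with a 1.2-fold lower number from compound 1 to compound 4 (0.08 log units; within the scatter), which leaves compound 3 alone at the low end of the series. Against the 2-hydroxy-2-methyloctyl ester, the reading is an at least 1.9-fold lower number from compound 2 to compound 4 (0.28 log units; that floor lies within the scatter), which gives a floor only, because compound 2 holds a limit: the limit of > 100000 nM in this assay, at which 1 of the 4 values shown sits.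

Ring loss and hydroxyl gain occur together between compound 3 and compound 4, so the compounds shown do not tell which of the two goes with the step. An open 2-ethylbutyl group or a six-membered oxan-2-yl ring on the same carbonyl carbon would separate them.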